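The source may report more compounds than this note shows. Statements on the series, on what has been measured and on what is new or still open speak of the compounds shown alone.

Working notes on the series, read in an ADME assay on L6 cells (Rattus norvegicus) for cytotoxicity, read by resazurin assay, with a stated time of 72 h; on this read-out lower numbers stand for stronger inhibition and higher numbers for weaker inhibition. Compound 1 `CC(C)(C)c1ccc(C(=O)NC(=O)c2ccccc2O)cc1` gives 2.3 ug/mL, compound 2 `O=C(NC(=O)c1ccccc1O)c1ccc(F)cc1` gives 38 ug/mL and compound 3 `N#Cc1ccc(C(=O)NC(=O)c2ccccc2O)cc1` gives 55 ug/mL. Compound 3 and compound 2 together form the high end of these numbers, with a 1.4-fold higher number from compound 2 to compound 3 (0.16 log units; within the scatter). The tert-butyl compound stands well apart, with a 17-fold higher number from compound 1 to compound 2 (1.22 log units; beyond the scatter) and a 24-fold higher number from compound 1 to compound 3 (1.38 log units; beyond the scatter).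

Compound 4 `CS(=O)(=O)c1ccc(C(=O)NC(=O)c2ccccc2O)cc1` has methylsulfonyl in place of cyano on an aromatic carbon. The two large steps both leave tert-butyl, which plays no part in this change. Among the compounds with values here, the closest precedent is the exchange of fluoro and cyano at the same place, the step within the scatter quoted above. Within the data shown here, no measured compound carries methylsulfonyl, so this precedent is thin and the range stays wide. No step beyond the scatter is expected in this assay. The expected step is a 1.1-fold higher number from compound 3 to compound 4 (0.04 log units; within the scatter). For compound 4 the estimated value is 60 ug/mL, with an expected range from 25 ug/mL to 110 ug/mL.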

Compound 4, half-maximal inhibitory concentration: > 100 ug/mL
Compound 4: only a limit was reported; the forecaster's own chance of this, stated with the estimate: 20%; middle value at least 1.6-fold (0.22 log units) away from the limit.
By their numbers in this assay, from the lowest: compound 1; then compounds 2 and 3 (each within the scatter of the next). At a limit, above all of these: compound 4.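

In this assay compound 4 is reported only as a limit, > 100 ug/mL, and it is the only compound shown that stands at one: the limit of > 100 ug/mL in this assay, at which 1 of the 4 values shown sits.

At this aromatic carbon, para to a large group, methylsulfonyl extends the high end of the series, with an at least 2.6-fold higher number from compound 2 to compound 4 (0.42 log units; beyond the scatter) and an at least 43-fold higher number from compound 1 to compound 4 (1.63 log units; beyond the scatter). Against the nitrile the reading is an at least 1.8-fold higher number from compound 3 to compound 4 (0.25 log units; that floor lies within the scatter), so this exchange establishes no real difference between the two groups, though the true gap may be larger.

The compounds shown leave open where the value of compound 4 lies past the limit, and so how far methylsulfonyl and cyano truly differ. Going by these compounds, how an amine, a carboxylic acid or a longer alkyl chain at this place would read, and whether any of them would approach the low number of the tert-butyl compound, also remains open.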